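Swapping Acetamido for Hydroxy: What to Expect of Compound 3

The source may hold more compounds than are shown below. What is called first, only, known or untested is meant among the compounds shown, and "the series" means these compounds.

Compound 1, `C=CC[C@H]1C[C@]2([C@@H](C)Cc3cc(C)c(OC)cc3F)OCOC2=CC1=O`: 650 nM
Compound 2, `C=CC[C@H]1C[C@]2([C@@H](C)Cc3cc(NC(C)=O)c(OC)cc3F)OCOC2=CC1=O`: 71 nM

Among the measured compounds shown here, in a functional assay on NCI-H460 cells (Homo sapiens) for antiproliferative activity, with a stated time of 72 h (on this read-out higher numbers stand for weaker inhibition and lower numbers for stronger inhibition), compound 2 gives the lower of the two numbers measured so far, and the step of a 9.2-fold lower number from compound 1 to compound 2 (0.96 log units; beyond the scatter) lies beyond the usual scatter. For the measured compounds named here, the only step measured, a 9.2-fold lower number from compound 1 to compound 2 (0.96 log units; beyond the scatter), thus shows that exchanging methyl for acetamido on the aromatic ring strengthens inhibition markedly.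

Compound 3, `C=CC[C@H]1C[C@]2([C@@H](C)Cc3cc(O)c(OC)cc3F)OCOC2=CC1=O`, has not been measured. Its change from compound 2 is hydroxy in place of acetamido on an aromatic carbon. Going by the values given here, no measured step bears directly on hydroxy at this position; the one measured step from compound 1 to compound 2 only shows that this aromatic carbon matters. Because a 9.2-fold lower number from compound 1 to compound 2 (0.96 log units; beyond the scatter) was modest, the estimate for compound 3 is placed between the two measured values, with wide uncertainty, expecting a weakening step a 2.1-fold higher number from compound 2 to compound 3 (0.32 log units; beyond the scatter). Compound 3 is estimated at 150 nM, ranging from 40 nM to 600 nM.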

Compound 3, half-maximal inhibitory concentration: 33 nM
Estimate against measurement, compound 3: 4.5-fold (0.66 log units) above; measured number outside the range, below it.
By their numbers in this assay, from the lowest: compound 3; then compound 2; then compound 1.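

In this assay, hydroxy in place of acetamido gives a 2.2-fold lower number from compound 2 to compound 3 (0.33 log units; beyond the scatter), so the gain at this aromatic carbon does not need the full acetamido group: a single oxygen, with far fewer heavy atoms, gives a lower number. Measured against methyl, hydroxy gives a 20-fold lower number from compound 1 to compound 3 (1.29 log units; beyond the scatter), and the three groups at this carbon now rank, from the lowest number, as hydroxy, acetamido and methyl. No evidence is available to explain this order.

The compounds shown leave open how other small groups at this carbon would compare, such as an amine or a carboxylic acid. They also leave open whether a chain longer than acetamido, such as propionamido, would give a higher or lower number than compound 2.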